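The source may report more compounds than this note shows. Statements on the series, on what has been measured and on what is new or still open speak of the compounds shown alone.

Compound 1 (`CCCOc1c(Br)cc(/C=C2\CCC/C(=C\c3ccccc3[N+](=O)[O-])C2=O)cc1OC`): 3.5 ug/mL
Compound 2 (`COc1cc(/C=C2\CCC/C(=C\c3ccc([N+](=O)[O-])cc3)C2=O)cc(Br)c1O`): 16.8 ug/mL
Compound 3 (`COc1cc(/C=C2\CCC/C(=C\c3ccc([N+](=O)[O-])cc3)C2=O)cc(Br)c1OC`): 9.86 ug/mL

In a functional assay on SK-N-MC cells (Homo sapiens) for cytotoxicity, read by MTT assay (a higher number here means a weaker inhibitor, a lower number a stronger inhibitor), compound 3 (9.86 ug/mL) lies within the scatter of compound 2 and above compound 1 by more than the scatter. Compound 4 (`CCCOc1c(Br)cc(/C=C2\CCC/C(=C\c3ccc([N+](=O)[O-])cc3)C2=O)cc1OC`) comes from compound 3 by ethyl in place of hydrogen on a saturated chain carbon bound to an oxygen on an aromatic ring, that is methoxy to propoxy (ethyl in place of hydrogen on a saturated chain carbon bound to an oxygen on an aromatic ring). Within the data shown here, the one measured step on that oxygen is a 1.7-fold lower number from compound 2 to compound 3 (0.23 log units; within the scatter) and it offers only weak guidance. Among the measured compounds shown here, compound 1 also carries propoxy and gives 3.5 ug/mL but is no direct pair. In this assay a step beyond the scatter is therefore not expected, with a slight lean to a lower number. The expected step is a 1.4-fold lower number from compound 3 to compound 4 (0.15 log units; within the scatter) (an estimate). For compound 4 the estimated value is 7 ug/mL (expected range 3 ug/mL to 16 ug/mL).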

Compound 4, half-maximal inhibitory concentration: 23.3 ug/mL
For compound 4 the middle estimate is 3.3-fold (0.52 log units) below the measured one; the measured number lies above the stated range.
By their numbers in this assay, from the lowest: compound 1; then compounds 3, 2 and 4 (each within the scatter of the next, the first and the last beyond it).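

In this assay, methoxy to propoxy on the oxygen on the aromatic ring gives a rise beyond the scatter (a 2.4-fold higher number from compound 3 to compound 4 (0.37 log units; beyond the scatter)), so the longer chain brings no gain here. Propyl in place of hydrogen on that oxygen stays within the scatter (a 1.4-fold higher number from compound 2 to compound 4 (0.14 log units; within the scatter)). With propoxy held, 4-nitrophenyl in place of 2-nitrophenyl gives a clear rise (a 6.7-fold higher number from compound 1 to compound 4 (0.82 log units; beyond the scatter)), so the nitrophenyl side also moves the number.

Nothing available explains these steps. Going by these compounds, whether ethoxy, a longer chain or a terminal amine on that oxygen would follow propoxy remains open.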